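A few compounds are considered here, and "the series" means these few. Any claim that something is new, unique, unknown or untested is made for them only; others in the source may bear on it.

In a functional assay on SMMC-7721 cells (Homo sapiens) for antiproliferative activity, read by MTT assay, with a stated time of 48 h (on this read-out higher numbers stand for weaker inhibition and lower numbers for stronger inhibition), three compounds built on one shared core have been measured. Compound 1 `CC(C)=CCC[C@]1(C)/C=C/[C@@H](OC(=O)C=C(C)C)[C@](C)(O)/C=C/C(=O)/C(C(=O)O)=C\C1`, which carries carboxy, reaches only a limit of the assay, > 10000 nM. Compound 2 `CC(C)=CCC[C@]1(C)/C=C/[C@@H](OC(=O)C=C(C)C)[C@](C)(O)/C=C/C(=O)/C(CN2CCCC2)=C\C1` gives 140 nM. Compound 3 `CC(C)=CCC[C@]1(C)/C=C/[C@@H](OC(=O)C=C(C)C)[C@](C)(O)/C=C/C(=O)/C(COC(=O)c2ccc([N+](=O)[O-])cc2)=C\C1` gives 2560 nM, the higher of the two actual numbers.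

Compound 4 `CSC(=S)OC/C1=C/C[C@](C)(CCC=C(C)C)/C=C/[C@@H](OC(=O)C=C(C)C)[C@](C)(O)/C=C/C1=O` departs from compound 3 on an oxygen on a saturated carbon: a group of 4 heavy atoms (2 carbon, 2 sulfur; no ring) in place of a group of 11 heavy atoms (7 carbon, 1 nitrogen, 3 oxygen; one six-membered aromatic ring of carbon only), on an oxygen on a saturated carbon. For the measured compounds named here, two measured steps bear on this change. The closer one is an 18-fold higher number from compound 2 to compound 3 (1.26 log units; beyond the scatter), a large step that changes the group on that same saturated chain carbon. The other, an at least 71-fold lower number from compound 1 to compound 2 (1.85 log units; beyond the scatter), is also large, but it replaces carboxy. Both show that this assay can respond strongly to changes in this part of the molecule, yet neither involves the entering group, so neither gives a direction. Compound 4 keeps the oxygen that compound 3, at 2560 nM, has on that carbon, so no large step is expected. The expected change is a 1.3-fold lower number from compound 3 to compound 4 (0.11 log units; within the scatter), with little confidence in its direction. For compound 4 the estimated value is 2000 nM, within an expected range of 400 nM to 9000 nM.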

Compound 4, half-maximal inhibitory concentration: 720 nM
Beside the measured number, compound 4's estimate is 2.8-fold (0.44 log units) above it; measured number inside the range.
By their numbers in this assay, from the lowest: compound 2; then compound 4; then compound 3. At a limit, above all of these: compound 1.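

In this assay, the step of a 3.6-fold lower number from compound 3 to compound 4 (0.55 log units; beyond the scatter) shows that the group on this oxygen still matters, and that (4-nitrophenyl)carbonyl with its aromatic ring is not needed for a number in this range. The new group does not reach the pyrrolidin-1-yl compound, with a 5.1-fold higher number from compound 2 to compound 4 (0.71 log units; beyond the scatter) on the whole side group at the saturated chain carbon. Against carboxy the step is an at least 13-fold lower number from compound 1 to compound 4 (1.14 log units; beyond the scatter) and can be read only as a bound: the limit of > 10000 nM in this assay, at which 1 of the 4 values shown sits.

As far as these compounds go, whether the sulfur atoms or the smaller size of the group on this oxygen goes with the lower number remains open; an acetyl or plain benzoyl group there would help separate the two. From the compounds shown here alone, it is also open whether another amine, such as morpholine, on the saturated chain carbon would match compound 2.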